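The compounds below may be only part of what the source reports. "The series", "measured", "known", "first", "only" and "open" are said of these compounds alone.

Of the compounds shown here, three sharing one core have been measured in a functional assay on NCI-H23 cells (Homo sapiens) for antiproliferative activity; on this read-out lower numbers stand for stronger inhibition of growth and higher numbers for weaker inhibition of growth. Compound 1 `O=C(CCC1=CCN(Cc2ccc(C(F)(F)F)cc2)C1=O)NO` gives 6640 nM, compound 2 `COc1cccc(CN2CC=C(CCC(=O)NO)C2=O)c1` gives 1970 nM, and compound 3 `O=C(CCC1=CCN(Cc2cccc(C(F)(F)F)c2)C1=O)NO` gives 680 nM. Compound 1 thus carries the highest number of the three: compound 2 sits nearest to it, and compound 3 lies furthest away. Among the measured compounds shown here, the only step between two measured compounds that differ in one place is a 2.9-fold lower number from compound 2 to compound 3 (0.46 log units; beyond the scatter), which places trifluoromethyl on the ring instead of methoxy.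

Compound 4 `O=C(CCC1=CCN(Cc2ccccc2)C1=O)NO` is the next compound awaiting measurement. It differs from compound 1 in one place: hydrogen in place of trifluoromethyl on an aromatic carbon, with hydrogen entering where trifluoromethyl leaves, at an aromatic carbon of the carbon-only six-membered ring, para to a large group. For the measured compounds named here, no measured step removes a substituent from that ring outright; the step from compound 2 to compound 3 swaps one substituent for another at a different place, so it bears on the change only loosely, showing that what sits on the ring can move this read-out by a modest amount. The values of compound 1 and compound 3 show that trifluoromethyl placed differently gives quite different numbers. A modest step in either direction is therefore expected, and compound 4 is estimated at 3500 nM, within 1200 nM to 10000 nM, which means an expected step of a 1.9-fold lower number from compound 1 to compound 4 (0.28 log units; within the scatter).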

Compound 4, concentration for 50% growth inhibition: 4290 nM
Compound 4: the middle estimate sits 1.2-fold (0.09 log units) below what was measured, within the range that was stated.
By their numbers in this assay, from the lowest: compound 3; then compound 2; then compounds 4 and 1 (each within the scatter of the next).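

Among the compounds shown here, compound 4 supplies the unsubstituted ring as a point of reference, which the earlier compounds lacked. In this assay the exchange of trifluoromethyl for hydrogen on the aromatic carbon para to a large group gives a 1.5-fold lower number from compound 1 to compound 4 (0.19 log units; within the scatter) and so makes no difference that rises above the scatter at this place. Against the other two compounds the same ring reads differently, since a 6.3-fold higher number from compound 3 to compound 4 (0.80 log units; beyond the scatter) and a 2.2-fold higher number from compound 2 to compound 4 (0.34 log units; beyond the scatter) both lie beyond the scatter, so trifluoromethyl as it sits in compound 3 and methoxy as it sits in compound 2 each go with a lower number than hydrogen, while compound 1 goes against this pattern.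

From the compounds shown here alone, whether a chlorine atom, a nitrile or an amine on the aromatic carbon para to a large group would stay within the scatter of compound 4, as trifluoromethyl does there, remains open. No evidence is at hand to say why the substituent on the ring matters in some of these compounds and not in compound 1.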